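A few compounds are considered here, and "the series" means these few. Any claim that something is new, unique, unknown or untested is made for them only; others in the source may bear on it.

Working notes on the series. Compound 3 `COc1cc(/C=C/c2cc(/C=C/c3cc(OC)c(OC)c(OC)c3)nc(OCCCCCBr)n2)cc(OC)c1OC` and compound 1 `COc1cc(/C=C/c2cc(/C=C/c3cc(OC)c(OC)c(OC)c3)nc(OCCCCBr)n2)cc(OC)c1OC` share one core; compound 2 `COc1ccc(/C=C/c2cc(/C=C/c3ccc(OC)c(OC)c3)nc(OCCCCCCBr)n2)cc1OC` and the still unmeasured compound 4 `COc1ccc(/C=C/c2cc(/C=C/c3ccc(OC)c(OC)c3)nc(OCCCCCBr)n2)cc1OC` share another. The difference between the two cores is not broken down here.

In a functional assay on HT-29 cells (Homo sapiens) for cytotoxicity, read by fluorescence and resazurin assay, with a stated time of 48 h (a lower number here means a stronger inhibitor, a higher number a weaker inhibitor), compound 3 gives > 20000 nM, which is a limit of the assay and not a number. Compound 1 gives > 20000 nM in this assay, again a limit. Compound 2 returns only a limit in this assay, > 20000 nM.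

The change from compound 3 to compound 1 is bromo in place of bromomethyl on a saturated chain carbon, four bonds along the chain from an oxygen on an aromatic ring. The step that the two limits leave unreadable from compound 3 to compound 1 cannot be sized, because both ends sit at the limit of > 20000 nM in this assay, at which 3 of the 3 values shown sit.

Compound 4 differs from compound 2 by bromo in place of bromomethyl on a saturated chain carbon, five bonds along the chain from an oxygen on an aromatic ring. Among the measured compounds shown here, this is the same kind of change as the one from compound 3 to compound 1, not the same change: there the bromo replaces bromomethyl on a saturated chain carbon four bonds along the chain from an oxygen on an aromatic ring, here five bonds along the chain. Among the compounds shown the change occurs twice in all, and the one measured instance gives no readable size.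

The step expected from compound 2 to compound 4 is a step that the limit leaves unreadable from compound 2 to compound 4, and this expectation rests on compound 2 sitting at the limit of > 20000 nM in this assay, at which 3 of the 3 values shown sit. Compound 4 is expected to give 30000 nM in this assay, within a range from 15000 nM to 100000 nM, most likely reported as a limit rather than a number.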

Compound 4, half-maximal inhibitory concentration: > 20000 nM
Compound 4: a limit, no number; the forecaster's own chance of this, stated with the estimate: 85%; the middle value lies beyond the limit too.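

Compound 4 adds no readable step: compound 2 and compound 4 both return a limit and not a number in this assay, so the change between them cannot be sized, and the whole series sits at that same limit: the limit of > 20000 nM in this assay, at which 4 of the 4 values shown sit.

The compounds shown leave open whether the bromo chain length or the difference between the two cores affects cytotoxicity in this cell line at all.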